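Two thiazolidinone cores with a halogen exchange

The source may hold more compounds than are shown below. What is called first, only, known or untested is meant among the compounds shown, and "the series" means these compounds.

Measured so far:
compound 1 `O=C1NC(=S)S/C1=C\c1cc(Cl)ccc1OCc1ccccc1` — 5000 nM
compound 2 `O=C1NC(=S)S/C1=C\c1cc(F)ccc1OCc1ccccc1` — 9000 nM
compound 3 `O=C1NC(=O)/C(=C/c2cc(F)ccc2OCc2ccccc2)S1` — 4000 nM

All numbers come from a functional assay on A549 cells (Homo sapiens) for inhibition, read by sulforhodamine B assay; on this read-out lower numbers stand for stronger inhibition of growth and higher numbers for weaker inhibition of growth. Compound 1 and compound 2 share one core and differ only in the change (chloro in place of fluoro on an aromatic carbon); the step of a 1.8-fold lower number from compound 2 to compound 1 (0.26 log units; within the scatter) is within the scatter, so nothing can be ordered here. Compound 3 carries a second core; its difference from compound 2 is not broken down here. Compound 3 gives 4000 nM, within the scatter of the number for compound 1 and below the number for compound 2 by more than the scatter.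

Compound 4 `O=C1NC(=O)/C(=C/c2cc(Cl)ccc2OCc2ccccc2)S1` is not yet measured. It differs from compound 3 by chloro in place of fluoro on an aromatic carbon, the same change as between compound 2 and compound 1. Going by the values given here, the expected step of a 1.7-fold lower number from compound 3 to compound 4 (0.24 log units; within the scatter) in this assay is put beside the measured one, a 1.8-fold lower number from compound 2 to compound 1 (0.26 log units; within the scatter), because only that step is available. For compound 4 the estimate is 2300 nM, with 1000 nM and 5000 nM as expected bounds.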

Compound 4, concentration for 50% growth inhibition: 5000 nM
Beside the measured number, compound 4's estimate is 2.2-fold (0.34 log units) below it; the range from low to high includes it.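

In this assay, chloro in place of fluoro on an aromatic carbon gives a 1.3-fold higher number from compound 3 to compound 4 (0.10 log units; within the scatter), so the two halogens cannot be ordered on this core, just as they cannot on the core of compound 1. Set side by side, the steps on the two cores show no difference that can be told from the scatter: the same change on two cores in this assay, a 1.8-fold lower number (0.26 log units; within the scatter) from compound 2 to compound 1 and a 1.3-fold higher number (0.10 log units; within the scatter) from compound 3 to compound 4, 2.3-fold (0.35 log units) apart, within the scatter of two such steps. This agrees with the change carrying over from one core to the other, but since neither step is itself readable, it does not show that the change acts alike on both cores or that it would behave the same way on a third.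

Open, from the compounds shown here alone, is whether a group other than a halogen at this place, such as a nitrile, a methoxy group or an amine, would give a step beyond the scatter in this assay. Also open, going by these compounds, is whether a longer chain carrying a carboxylic acid on the ring nitrogen of either core would do so.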